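Swapping the Hydroxy-Methoxyphenyl Arm for Chlorophenyl

This account rests on a few compounds, and the source may have more. Where it says the series, first, only, none or still open, it means among the compounds named here.

Of the compounds shown here, three sharing one core have been tested in a functional assay on HL-60 cells (Homo sapiens) for cytotoxicity; on this read-out lower numbers stand for higher toxicity in this test and higher numbers for lower toxicity in this test. Compound 1 `COc1cc(/C=C2\CCC/C(=C\c3ccc([N+](=O)[O-])cc3)C2=O)ccc1O` gives 3400 nM. Compound 3 `COc1ccc(/C=C2\CCC/C(=C\c3ccc([N+](=O)[O-])cc3)C2=O)cc1OC` gives 4300 nM, and compound 2 `COc1ccc(/C=C2\Cc3ccccc3/C(=C\c3ccc([N+](=O)[O-])cc3)C2=O)cc1` gives 4400 nM. Compound 1 thus stands within the usual scatter of both other compounds, so no one of the three can be set apart from the others on these numbers.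

Compound 4 `O=C1/C(=C/c2ccc(Cl)cc2)CCC/C1=C\c1ccc([N+](=O)[O-])cc1` has not yet been measured in this assay. It differs from compound 1 in one place: 4-chlorophenyl in place of 4-hydroxy-3-methoxyphenyl on a double-bonded chain carbon bound to a double-bonded ring carbon. For the measured compounds named here, only one measured step touches the same arm of the molecule, the change from compound 1 to compound 3, which gave a 1.3-fold higher number from compound 1 to compound 3 (0.10 log units; within the scatter). Going by the values given here, no measured step replaces the whole aryl group, so the data give no direct guide for this larger change; the one related step suggests little movement.

Compound 4 is therefore expected to give about 3500 nM, with a range from 1500 nM to 9000 nM, which means an expected step of a 1.0-fold higher number from compound 1 to compound 4 (0.01 log units; within the scatter).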

Compound 4, half-maximal cytotoxic concentration: 4100 nM
Beside the measured number, compound 4's estimate is 1.2-fold (0.07 log units) below it, within the range that was stated.
By their numbers in this assay, from the lowest: compounds 1, 4, 3 and 2 (each within the scatter of the next).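

In this assay, exchanging the whole 4-hydroxy-3-methoxyphenyl group for 4-chlorophenyl gives a 1.2-fold higher number from compound 1 to compound 4 (0.08 log units; within the scatter), so an aryl group carrying hydrogen-bond donors and acceptors can give way to one with neither and the number stays within the scatter. The earlier change at this position, a 1.3-fold higher number from compound 1 to compound 3 (0.10 log units; within the scatter), altered only one oxygen substituent, whereas this result shows that the read-out also holds when the substituents on the ring are all different. No supporting data bear on why the read-out holds across this change.

The compounds shown leave open whether this insensitivity extends to a ring carrying an amine or a carboxylic acid instead of chlorine. They also leave open whether a longer chain in place of the aryl group would shift the number.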